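Working notes: from compound 2 to compound 3

The source may report more compounds than this note shows. Statements on the series, on what has been measured and on what is new or still open speak of the compounds shown alone.

- compound 1 `CCCc1ccc(C(=O)Nc2cc(C(=O)O)cc(C(=O)O)c2)cc1` – 94.2 mg/kg
- compound 2 `CCCOc1ccc(C(=O)Nc2cc(C(=O)O)cc(C(=O)O)c2)cc1` – 78 mg/kg

In a functional assay on the whole organism (stomach) with Rattus norvegicus as the target (on this read-out higher numbers stand for an effect only at larger amounts of compound and lower numbers for an effect already at smaller amounts), compound 2 gives 78 mg/kg, within the scatter of compound 1. Compound 3 `N#Cc1ccc(C(=O)Nc2cc(C(=O)O)cc(C(=O)O)c2)cc1` carries cyano in place of propoxy on an aromatic carbon. Going by the values given here, the only measured step bearing on this, a 1.2-fold lower number from compound 1 to compound 2 (0.08 log units; within the scatter), exchanges propyl for propoxy at the same place and stays within the scatter. Among the compounds with values here, no measured compound carries cyano, so the basis is thin and no step beyond the scatter is expected. The expected step is a 1.2-fold higher number from compound 2 to compound 3 (0.06 log units; within the scatter). For compound 3 the estimated value is 90 mg/kg, with an expected range of 35 mg/kg to 230 mg/kg.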

Compound 3, dose for 50% inhibition: 32.1 mg/kg
The estimate for compound 3 lay 2.8-fold (0.45 log units) above the measured number, outside the stated range (below it).
By their numbers in this assay, from the lowest: compound 3; then compounds 2 and 1 (each within the scatter of the next).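

At this position, para to a large group, the propyl and propoxy compounds stayed within the scatter of each other, but cyano moves the number in this assay, with a 2.4-fold lower number from compound 2 to compound 3 (0.39 log units; beyond the scatter) and a 2.9-fold lower number from compound 1 to compound 3 (0.47 log units; beyond the scatter) in the series. The position therefore responds to the group it carries, and the change to cyano brings the effect at smaller amounts of compound. Nothing measured here accounts for this shift.

On these data alone, whether it follows from cyano itself or from the loss of the propyl and propoxy chains stays open. Where chlorine or an amine at this place would fall is also open.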